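A few compounds are considered here, and "the series" means these few. Any claim that something is new, unique, unknown or untested is made for them only; others in the source may bear on it.

Series around a shared core, varied at the group on the oxygen on a saturated carbon. Compound 1 `COC(=O)c1cc(OCC(=O)[C@H](CC(=O)O)NC(=O)[C@@H](NC(=O)COc2cccc3ccccc23)C(C)C)no1` carries the 5-(methoxycarbonyl)-1,2-oxazol-3-yl group; in a functional assay on Jurkat cells (Homo sapiens) for inhibition (on this read-out lower numbers stand for stronger inhibition and higher numbers for weaker inhibition), compound 1 gives 71000 nM. Compound 2 `CC(C)[C@H](NC(=O)COc1cccc2ccccc12)C(=O)N[C@@H](CC(=O)O)C(=O)COc1nc2ccccc2[nH]1` carries 1H-benzimidazol-2-yl at that place. For compound 2 this assay reports only a limit, > 200000 nM. Among the measured compounds shown here, the one measured step, an at least 2.8-fold higher number from compound 1 to compound 2 (0.44 log units; beyond the scatter), lands on (the limit of > 200000 nM in this assay, at which 1 of the 2 values shown sits), so compound 2 stands at the weaker end of the two values known. Compound 3 `CC(C)[C@H](NC(=O)COc1cccc2ccccc12)C(=O)N[C@@H](CC(=O)O)C(=O)COc1cc(C(F)(F)F)ncn1` is the next change from compound 2: 6-(trifluoromethyl)pyrimidin-4-yl in place of 1H-benzimidazol-2-yl on an oxygen on a saturated carbon. For the measured compounds named here, no measured step covers this exact exchange; the step from compound 1 to compound 2 shows only that swapping the group at this position can move this assay beyond the scatter. A move back toward the region of compound 1 is expected for compound 3, as an at least 3.3-fold lower number from compound 2 to compound 3 (0.52 log units; beyond the scatter). The estimate for compound 3 is 60000 nM, with a range from 10000 nM to 200000 nM.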

Compound 3, half-maximal inhibitory concentration: > 200000 nM
Compound 3: only a limit was reported; the forecaster's own chance of this, stated with the estimate: 30%; middle value at least 3.3-fold (0.52 log units) away from the limit.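

Replacing 5-(methoxycarbonyl)-1,2-oxazol-3-yl with 6-(trifluoromethyl)pyrimidin-4-yl on the oxygen on a saturated carbon gives an at least 2.8-fold higher number from compound 1 to compound 3 (0.44 log units; beyond the scatter) in this assay, so a second, quite different group also falls short of the 1,2-oxazole group. The 1H-benzimidazol-2-yl group has 1 hydrogen-bond donor and the 6-(trifluoromethyl)pyrimidin-4-yl group has 0, yet both compound 2 and compound 3 are reported only as limits. The step from compound 2 to compound 3 cannot be read because both values are limits: the limit of > 200000 nM in this assay, at which 2 of the 3 values shown sit.

From the compounds shown here alone, how far compound 2 and compound 3 lie from each other remains open, as does whether any group at this place gives a lower number than compound 1, at 71000 nM. Going by these compounds, the effect of a carboxylic acid in place of the methoxycarbonyl group, or of an amine on the 1,2-oxazole ring, is also open.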